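Working notes: aryl swap from compound 2 to compound 4

The source may report more compounds than this note shows. Statements on the series, on what has been measured and on what is new or still open speak of the compounds shown alone.

Measured so far in an ADME assay on the whole organism for cytotoxicity, with Artemia salina as the target, with a stated time of 24 h; a higher number here means that more compound is needed for the effect, a lower number that less compound is needed:
compound 1 `COc1cccc(/C=C/C(=O)c2ccccc2NC(=O)NS(=O)(=O)c2ccc(C)cc2)c1` gives 23.2 ug/mL
compound 2 `COc1ccc(/C=C/C(=O)c2ccccc2NC(=O)NS(=O)(=O)c2ccc(C)cc2)cc1OC` gives 12.9 ug/mL
compound 3 `Cc1ccc(S(=O)(=O)NC(=O)Nc2ccccc2C(=O)/C=C/c2ccccc2O)cc1` gives 32.3 ug/mL

On the numbers shown, compound 2 has the lowest value of the three. The step of a 1.8-fold lower number from compound 1 to compound 2 (0.25 log units; within the scatter) is within the scatter, so compound 2 and compound 1 cannot be ordered against each other; the step of a 2.5-fold higher number from compound 2 to compound 3 (0.40 log units; beyond the scatter) is beyond the scatter, and that is the only separation that holds.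

Compound 4 `Cc1ccc(S(=O)(=O)NC(=O)Nc2ccccc2C(=O)/C=C/c2ccc(Cl)cc2)cc1` differs from compound 2 in one place: 4-chlorophenyl in place of 3,4-dimethoxyphenyl on a double-bonded chain carbon bound to a double-bonded chain carbon. For the measured compounds named here, the steps that bear on this are the two earlier swaps of the aryl group at the same place, a 1.4-fold higher number from compound 1 to compound 3 (0.14 log units; within the scatter) (within the scatter) and a 2.5-fold higher number from compound 2 to compound 3 (0.40 log units; beyond the scatter) (modest). Both aryl swaps away from a methoxy-bearing ring moved the number upward, and the change to compound 4 also removes the 3,4-dimethoxyphenyl, so a small step upward in this assay is expected, of about a 1.6-fold higher number from compound 2 to compound 4 (0.19 log units; within the scatter), with a result within the scatter of compound 2 remaining quite possible. Going by the values given here, no measured compound carries 4-chlorophenyl, so the range is kept wide. Compound 4 is therefore expected to give about 20 ug/mL in this assay, between 9 ug/mL and 45 ug/mL.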

Compound 4, concentration for half-maximal effect: 6.92 ug/mL
Estimate against measurement, compound 4: 2.9-fold (0.46 log units) above; measured number outside the range, below it.
By their numbers in this assay, from the lowest: compounds 4, 2, 1 and 3 (each within the scatter of the next, the first and the last beyond it).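

In this assay, the place on a double-bonded chain carbon bound to a double-bonded chain carbon accepts 4-chlorophenyl, a ring with neither methoxy nor hydroxy, without the number leaving the range of the 3,4-dimethoxyphenyl compound: a 1.9-fold lower number from compound 2 to compound 4 (0.27 log units; within the scatter). Methoxy on the ring is therefore not needed for a low number here, and the earlier reading that swaps away from a methoxy-bearing ring move the number upward does not extend to this swap. The separations are against the other two rings, a 4.7-fold lower number from compound 3 to compound 4 (0.67 log units; beyond the scatter) and a 3.4-fold lower number from compound 1 to compound 4 (0.53 log units; beyond the scatter), the latter being the first step from compound 1 beyond the scatter, while compound 2 goes against any reading that 4-chlorophenyl stands apart from every other ring; nothing at hand accounts for these differences.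

Whether the chlorine itself matters stays open, since 4-chlorophenyl is the only halogen-bearing ring among the compounds shown, and an unsubstituted phenyl or a 4-fluorophenyl at this place would be needed to decide it. Also open, from the compounds shown here alone, is how a ring carrying an amine or a carboxylic acid would read at this place.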